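A few compounds are considered here, and "the series" means these few. Any claim that something is new, unique, unknown or untested is made for them only; others in the source may bear on it.

Compound 1 `CC(C)(C)c1cc(C(=O)NCCC2CCN(Cc3ccccc3)CC2)cc(C(C)(C)C)c1O` gives 89200 nM in an assay on isolated protein for inhibition of Amine oxidase [flavin-containing] B (Homo sapiens), read by fluorescence, with stated times of 15 min and 20 min; on this read-out higher numbers stand for weaker inhibition and lower numbers for stronger inhibition; compound 2 `CC(C)(C)c1cc(/C=C/C(=O)NCCC2CCN(Cc3ccccc3)CC2)cc(C(C)(C)C)c1O` gives 8500 nM; compound 3 `COc1ccc(CN2CCC(CCNC(=O)/C=C/c3cc(C(C)(C)C)c(O)c(C(C)(C)C)c3)CC2)cc1` gives 6700 nM.

Compound 3 carries the lowest of the three numbers. Its nearest neighbour is compound 2, and the step of a 1.3-fold lower number from compound 2 to compound 3 (0.10 log units; within the scatter) lies within the scatter, so the two cannot be placed in order. Compound 1 stands far from both: its number is well beyond the scatter from that of compound 3.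

Compound 4 `Cc1ccccc1CN1CCC(CCNC(=O)/C=C/c2cc(C(C)(C)C)c(O)c(C(C)(C)C)c2)CC1` has not been measured. Relative to compound 3 it differs by 2-methylphenyl in place of 4-methoxyphenyl on a saturated chain carbon bound to an amine nitrogen in a ring. For the measured compounds named here, only one measured step concerns the same benzyl position, namely a 1.3-fold lower number from compound 2 to compound 3 (0.10 log units; within the scatter), which was within the scatter; the large gap between compound 1 and compound 2 concerns a different part of the molecule and does not bear on this change. Compound 4 is therefore expected to sit close to compound 3, with a step of a 1.0-fold higher number from compound 3 to compound 4 (0.02 log units; within the scatter) that stays within the scatter. The estimate for compound 4 is 7000 nM, with a range from 3000 nM to 16000 nM.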

Compound 4, half-maximal inhibitory concentration: 7200 nM
Compound 4: the middle estimate sits 1.0-fold (0.01 log units) below what was measured; the measured number falls inside the stated range.
By their numbers in this assay, from the lowest: compounds 3, 4 and 2 (each within the scatter of the next); then compound 1.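

Replacing 4-methoxybenzyl with 2-methylbenzyl on a saturated chain carbon bound to an amine nitrogen in a ring leaves the number in this assay within the scatter (a 1.1-fold higher number from compound 3 to compound 4 (0.03 log units; within the scatter)). Compound 4 also stays within the scatter of the unsubstituted benzyl compound (a 1.2-fold lower number from compound 2 to compound 4 (0.07 log units; within the scatter)), so neither the methyl nor the methoxy group separates from plain benzyl, and the two substituted rings, which differ in group and in printed name, cannot be told apart. No measurement here explains why this position responds so little.

The compounds shown leave open whether a group of another kind on this ring, such as a carboxylic acid or an amine, would move the number beyond the scatter. They also leave open whether a pyridine in place of the phenyl ring, or a longer chain to it, would do so.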